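The source may hold more compounds than are shown below. What is called first, only, known or untested is meant among the compounds shown, and "the series" means these compounds.

Compound 2 `CCOc1nc(N)c2nc(O)n(Cc3ccccc3)c2n1` stands at the lower end of the two numbers shown in a functional assay (spleen, spleen) for activation, with Mus musculus as the target (on this read-out higher numbers stand for an effect only at larger amounts of compound and lower numbers for an effect already at smaller amounts), where compound 2 gives 0.1 uM. Its nearest neighbour, compound 1 `Nc1ncnc2c1nc(O)n2Cc1ccc(Cl)cc1`, gives 10 uM in this assay, a gap that lies beyond the usual scatter. Compound 3 `Nc1ncnc2c1nc(I)n2Cc1ccccc1` is known in this assay only as a limit: compound 3 gives > 10 uM, which is a limit of the assay and not a number (the limit of > 10 uM in this assay, at which 1 of the 3 values shown sits). No pair among these three differs in only one place, so no single measured step can be drawn from them.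

Compound 4 `CSc1nc(N)c2nc(O)n(Cc3ccccc3)c2n1` has not yet been measured. It differs from compound 2 by methylsulfanyl in place of ethoxy on an aromatic carbon. No comparable exchange has been measured here; the expectation rests on compound 2 and the structural change alone, and the step is expected to be small, toward a higher number, close to the scatter. For compound 4 the estimate in this assay is 0.3 uM, with a range from 0.1 uM to 3 uM. The expected step is a 3.0-fold higher number from compound 2 to compound 4 (0.48 log units; beyond the scatter).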

Compound 4, minimum effective concentration: 0.1 uM
Compound 4: middle estimate off by 3.0-fold (0.48 log units), on the high side, within the range that was stated.
By their numbers in this assay, from the lowest: compounds 2 and 4 (each within the scatter of the next); then compound 1.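

In this assay, the read-out shows no change at the digits printed from compound 2 to compound 4 (within the scatter) when methylsulfanyl takes the place of ethoxy on the aromatic carbon between two ring nitrogen atoms. Among the compounds shown, this is the first exchange that can be read at this position, and it shows that the low number of compound 2 is not tied to ethoxy alone, as a sulfur-linked group serves equally within the scatter. Nothing given here offers a reason for this outcome.

From the compounds shown here alone, what the position does with an amine, a longer chain such as butoxy, or a sulfur-linked chain longer than methylsulfanyl remains open. Compound 1 and compound 3 differ from compound 2 in more than one place, so the effect of having any group at this position cannot be read from them.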